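Indazole series: aryl versus alkyl groups on ring nitrogen

A few compounds are considered here, and "the series" means these few. Any claim that something is new, unique, unknown or untested is made for them only; others in the source may bear on it.

Measured so far in a functional assay on cells (Platelet, Homo sapiens) for inhibition; on this read-out higher numbers stand for weaker inhibition and lower numbers for stronger inhibition:
compound 1 `CCOC(=O)c1ccc(-c2nn(Cc3ccc(OC)cc3)c3ccccc23)cc1`, 620 nM;
compound 2 `CCOC(=O)c1ccc(-c2nn(Cc3ccncc3)c3ccccc23)cc1`, 5630 nM;
compound 3 `CCOC(=O)c1ccc(-c2nn(C(C)C)c3ccccc23)cc1`, 650 nM.

Compound 3 stands second highest of the three numbers. Its nearest neighbour is compound 1, with a difference within the scatter (a 1.0-fold higher number from compound 1 to compound 3 (0.02 log units; within the scatter)); its furthest is compound 2, beyond the scatter (an 8.7-fold lower number from compound 2 to compound 3 (0.94 log units; beyond the scatter)). The remaining measured step, a 9.1-fold higher number from compound 1 to compound 2 (0.96 log units; beyond the scatter), is the only one of modest size apart from that one.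

Compound 4 `CCOC(=O)c1ccc(-c2nn(-c3ccccc3)c3ccccc23)cc1` differs from compound 3 by phenyl in place of isopropyl on an aromatic nitrogen. Within the data shown here, no measured step puts an aromatic ring directly on this nitrogen. Among the measured compounds shown here, the steps that bear on the change are a 1.0-fold higher number from compound 1 to compound 3 (0.02 log units; within the scatter), which shows a benzyl-type group and isopropyl at this position giving numbers within the scatter of each other, and an 8.7-fold lower number from compound 2 to compound 3 (0.94 log units; beyond the scatter), which shows a modest shift for a pyridinylmethyl group. Phenyl carries no ring nitrogen, so the expectation for compound 4 in this assay is a step of no more than the scatter, no change at the digits printed from compound 3 to compound 4 (within the scatter), with the range widened because the direct attachment is untested. Compound 4 is therefore estimated at 650 nM, between 200 nM and 2200 nM.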

Compound 4, half-maximal inhibitory concentration: 2640 nM
Compound 4: the middle estimate sits 4.1-fold (0.61 log units) below what was measured, outside the stated range (above it).
By their numbers in this assay, from the lowest: compounds 1 and 3 (each within the scatter of the next); then compound 4; then compound 2.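

In (this assay) phenyl directly on the aromatic nitrogen does not match the groups joined through a saturated carbon: isopropyl gives way to phenyl with a clear loss (a 4.1-fold higher number from compound 3 to compound 4 (0.61 log units; beyond the scatter)), and 4-methoxybenzyl does too (a 4.3-fold higher number from compound 1 to compound 4 (0.63 log units; beyond the scatter)). The agreement seen between isopropyl and 4-methoxybenzyl therefore does not extend to every group at this position. Phenyl also stands apart from (pyridin-4-yl)methyl (a 2.1-fold lower number from compound 2 to compound 4 (0.33 log units; beyond the scatter)), so the four compounds fall on three levels, and a weaker number here does not require a ring nitrogen in the entering group.

Still open, going by these compounds, is whether a pyridin-4-yl group directly on this nitrogen, or a phenyl carrying an amine or a carboxylic acid, would stay near compound 4. Also open, on these data alone, is whether a longer chain such as n-butyl would stay with compound 3. No measured evidence bears on the cause of these steps.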